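The source may report more compounds than this note shows. Statements on the series, on what has been measured and on what is new or still open speak of the compounds shown alone.

Measured compounds:
- compound 1, `CC(C)C[C@@H]1O[C@H](COCc2ccccc2)[C@@H](OCc2ccccc2)[C@H](OCc2ccccc2)[C@H]1O`, 45200 nM
- compound 2, `O[C@@H]1[C@@H](OCc2ccccc2)[C@H](OCc2ccccc2)[C@@H](COCc2ccccc2)O[C@H]1CC1CCCCC1`, 4400 nM

In a functional assay on HOS cells (Homo sapiens) for antiproliferative activity, read by sulforhodamine B assay (on this read-out lower numbers stand for stronger inhibition of growth and higher numbers for weaker inhibition of growth), compound 2 holds the lowest of the two numbers shown; compound 1 is the nearest, and the single measured step is a 10-fold lower number from compound 1 to compound 2 (1.01 log units; beyond the scatter), which replaces isopropyl with cyclohexyl on a saturated chain carbon bound to a saturated ring carbon. Compound 3, `O[C@@H]1[C@@H](OCc2ccccc2)[C@H](OCc2ccccc2)[C@@H](COCc2ccccc2)O[C@H]1Cc1ccccc1`, differs from compound 2 in one place: phenyl in place of cyclohexyl on a saturated chain carbon bound to a saturated ring carbon. No measured step exchanges cyclohexyl for phenyl, so the only shown step bears on it indirectly, saying merely that a larger ring at this position gave a large gain over the smaller branch. Since compound 3 keeps a six-membered ring of the same size, the expected step of a 1.3-fold higher number from compound 2 to compound 3 (0.10 log units; within the scatter) is small, with no confident direction beyond the scatter. Compound 3 is therefore estimated at 5500 nM, within a range of 1500 nM to 20000 nM.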

Compound 3, concentration for 50% growth inhibition: 29200 nM
Compound 3: middle estimate off by 5.3-fold (0.73 log units), on the low side, outside the stated range (above it).
By their numbers in this assay, from the lowest: compound 2; then compounds 3 and 1 (each within the scatter of the next).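

In this assay the exchange of cyclohexyl for phenyl on a saturated chain carbon bound to a saturated ring carbon is not a neutral swap, giving a 6.6-fold higher number from compound 2 to compound 3 (0.82 log units; beyond the scatter), although each group is a six-membered ring of carbon only. Ring size alone therefore does not carry the earlier gain: the phenyl group stands level with the isopropyl group, at a 1.5-fold lower number from compound 1 to compound 3 (0.19 log units; within the scatter), and of these three groups only cyclohexyl is set apart. Nothing available here explains the difference between the non-aromatic and the aromatic ring.

The compounds shown leave open whether cyclopentyl or cycloheptyl in this place would match cyclohexyl. They also leave open how a longer chain between the cyclohexyl ring and the core, or an amine on that ring, would change the growth inhibition.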